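Nitro on the fused ring in two related cores

The compounds below may be only part of what the source reports. "The series", "measured", "known", "first", "only" and "open" are said of these compounds alone.

Compound 1 `CCn1cc(-c2nc3ccccc3o2)c(=O)c2cc(F)c(N3CCN(C)CC3)cc21` is the reference point in a functional assay on A2780 cells (Homo sapiens) for cytotoxicity, read by MTT assay, with a stated time of 48 h (a lower number here means a stronger inhibitor, a higher number a weaker inhibitor), where compound 1 gives 700 nM. Compound 3 `CCn1cc(-c2nc3ccc([N+](=O)[O-])cc3o2)c(=O)c2cc(F)c(N3CCN(C)CC3)cc21` carries a nitro in place of hydrogen on an aromatic carbon, and in this assay compound 3 gives 39600 nM; the step is a 57-fold higher number from compound 1 to compound 3 (1.75 log units; beyond the scatter).

Compound 2 `CCn1cc(-c2nc3ccccc3s2)c(=O)c2cc(F)c(N3CCNCC3)cc21` has a different core, and the difference between the two cores is not broken down here. In this assay compound 2 gives 11300 nM, which stands well above compound 1 and below compound 3.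

Compound 4 `CCn1cc(-c2nc3ccc([N+](=O)[O-])cc3s2)c(=O)c2cc(F)c(N3CCNCC3)cc21` is not yet measured. Its change from compound 2 is nitro in place of hydrogen on an aromatic carbon, the same change as that from compound 1 to compound 3, at a place described in the same words. Among the compounds with values here, the expectation is that compound 4 will show a step of about a 13-fold higher number from compound 2 to compound 4 (1.12 log units; beyond the scatter) in this assay, resting on the single precedent of a 57-fold higher number from compound 1 to compound 3 (1.75 log units; beyond the scatter), taken with some caution because compound 2 already starts from 11300 nM, where a large step may run past what the measurement can resolve. The estimated value for compound 4 is 150000 nM, with a range from 40000 nM to 600000 nM.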

Compound 4, half-maximal inhibitory concentration: 700 nM
Beside the measured number, compound 4's estimate is 210-fold (2.33 log units) above it, and the stated range ends above it.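

In this assay, nitro in place of hydrogen on an aromatic carbon does not carry over from one core to the other: the new step is a 16-fold lower number from compound 2 to compound 4 (1.21 log units; beyond the scatter), opposite in direction to the earlier one. Set side by side, the two steps differ beyond what repeated measurement would give: the same change on two cores in this assay, a 57-fold higher number (1.75 log units; beyond the scatter) from compound 1 to compound 3 and a 16-fold lower number (1.21 log units; beyond the scatter) from compound 2 to compound 4, 910-fold (2.96 log units) apart, beyond the scatter of two such steps The result of this change on one core therefore gives no guide to its result on the other in this series, but it does not show what in the cores separates the two outcomes, and each direction rests on a single pair of compounds.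

As far as these compounds go, it remains open whether the opposite steps are particular to nitro or would also appear with another group at the same place, such as an amine or a nitrile, on both cores. From the compounds shown here alone, it also remains open which of the differences between the two cores goes with the reversal.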